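The compounds below may be only part of what the source reports. "The series", "measured", "known", "first", "only" and "open" are said of these compounds alone.

In an assay on CHO cells for displacement of a labelled ligand from Alpha-1D adrenergic receptor (Homo sapiens), with a stated time of 30 min (on this read-out higher numbers stand for weaker inhibition and lower numbers for stronger inhibition), three compounds have been measured. Compound 1 `CCCN(CCC)c1nc(N2CCN(C(=O)c3ccco3)[C@@H]3CCCC[C@@H]32)nc2cc(OC)c(OC)cc12` gives 0.0631 nM. Compound 2 `COc1cc2nc(N3CCN(C(C)=O)[C@@H]4CCCC[C@@H]43)nc(N)c2cc1OC` gives 0.151 nM, and its mirror image, compound 3 `COc1cc2nc(N3CCN(C(C)=O)[C@H]4CCCC[C@H]43)nc(N)c2cc1OC`, gives 105 nM. The step of a 700-fold higher number from compound 2 to compound 3 (2.84 log units; beyond the scatter) is by far the largest gap among the three, and it arises because the fact that compounds 2 and 3 differ only in the configuration as drawn — nothing else about the two molecules differs. Compound 2 therefore stands in the middle of the three: its number is higher than that of compound 1, and very much lower than that of compound 3.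

Compound 4 `COc1cc2nc(N3CCN(C(=O)OCc4ccccc4)[C@@H]4CCCC[C@@H]43)nc(N)c2cc1OC` keeps the whole of compound 2, including the configuration at both saturated ring carbons, and changes only the group on the carbonyl: benzyloxy in place of methyl on a carbonyl carbon. Among the measured compounds shown here, no measured pair shows exactly this change. Compound 1 carries a different acyl group on the same nitrogen, but it also differs from compound 2 elsewhere, so its lower number cannot be assigned to the acyl group alone. For the measured compounds named here, the one measured step, the inversion of configuration, bears on a place that compound 4 leaves untouched. The expectation is thus a step of a 1.3-fold lower number from compound 2 to compound 4 (0.10 log units; within the scatter), with the configuration of compound 2 retained and a larger group in an unexplored position. Compound 4 is estimated at 0.12 nM, within a range from 0.025 nM to 0.6 nM.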

Compound 4, inhibition constant: 0.0398 nM
Estimate against measurement, compound 4: 3.0-fold (0.48 log units) above, within the range that was stated.
By their numbers in this assay, from the lowest: compounds 4 and 1 (each within the scatter of the next); then compound 2; then compound 3.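

In this assay, putting benzyloxy in place of methyl on the carbonyl carbon gives a 3.8-fold lower number from compound 2 to compound 4 (0.58 log units; beyond the scatter), so this position accepts a much larger group, one that brings a six-membered aromatic ring, and the number falls rather than rises. Among the compounds shown here, this is the first measured change at this carbonyl carbon with everything else held fixed, so the place now has a modest effect of its own, whereas the earlier single-place step concerned only configuration at the saturated ring carbons. The comparison of the two mirror images has no bearing on this exchange, and nothing measured here accounts for the lower number.

Benzyloxy brings its oxygen and its benzene ring together, so the compounds shown leave open which of the two matters, a question that ethoxy or phenyl on the same carbonyl carbon would help to separate. Also open, from the compounds shown here alone, are whether an amine such as aminomethyl or a carboxylic acid would be accepted at this place, and whether benzyloxy would lower the number in the mirror-image series of compound 3 as well.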